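The compounds below may be only part of what the source reports. "The series", "measured", "known", "first", "only" and "open" are said of these compounds alone.

In a functional assay on aorta (Rattus norvegicus, strain Sprague-Dawley) (a lower number here means that less compound is needed, a higher number that more compound is needed for the effect), compound 1 `Cc1nn(-c2ccccc2)c2nc(OCc3ccccc3F)c(-c3nc(N)cc(N)n3)cc12` gives 2200 nM and compound 3 `Cc1cccc(COc2nc3c(cc2-c2nc(N)cc(N)n2)c(C)nn3-c2ccccc2)c1` gives 990 nM, the lower of the two numbers available. Compound 2 `Cc1nn(-c2ccccc2)c2nc(OCc3ccc(F)cc3)c(-c3nc(N)cc(N)n3)cc12` offers no comparison, as its result reads "not determined" (no result reported). Compound 4 `Cc1nn(-c2ccccc2)c2nc(OCc3ccc(C(F)(F)F)cc3)c(-c3nc(N)cc(N)n3)cc12` keeps the shared core and carries 4-(trifluoromethyl)phenyl in place of the 3-methylphenyl of compound 3, on a saturated chain carbon bound to an oxygen on an aromatic ring: 4-(trifluoromethyl)phenyl in place of 3-methylphenyl on a saturated chain carbon bound to an oxygen on an aromatic ring. For the measured compounds named here, only one measured step involves this place, a 2.2-fold lower number from compound 1 to compound 3 (0.35 log units; beyond the scatter), which is modest and involves different groups. It suggests the likely size of a change but not its direction. The expected step is small, a 1.3-fold higher number from compound 3 to compound 4 (0.12 log units; within the scatter). For compound 4 the estimated value is 1300 nM, with an expected range of 450 nM to 3700 nM.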

Compound 4, half-maximal effective concentration: 1600 nM
The estimate for compound 4 lay 1.2-fold (0.09 log units) below the measured number; the measured number falls inside the stated range.
By their numbers in this assay, from the lowest: compounds 3, 4 and 1 (each within the scatter of the next, the first and the last beyond it).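

In this assay, 4-(trifluoromethyl)phenyl in place of 3-methylphenyl gives a 1.6-fold higher number from compound 3 to compound 4 (0.21 log units; within the scatter) and in place of 2-fluorophenyl gives a 1.4-fold lower number from compound 1 to compound 4 (0.14 log units; within the scatter) while both steps stay within the scatter. This position on the saturated chain carbon therefore takes a group of 10 heavy atoms instead of 7 with no readable difference from either compound, although compound 1 and compound 3 lie beyond the scatter of each other. On these data alone, whether an amine or a carboxylic acid on this phenyl ring would shift the number stays open. Nothing measured here says why the numbers fall as they do.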